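The compounds below may be only part of what the source reports. "The series", "measured", "known", "first", "only" and "open" are said of these compounds alone.

Working notes on the series. In a functional assay on cells (Mast cell, Mus musculus, strain C57BL/6) for activation, read by fluorescence, with a stated time of 15 min (a lower number here means that less compound is needed, a higher number that more compound is needed for the effect), compound 1 `CCCCCCCCCCCCCCCCCC(=O)OC[C@@H](O)COP(=O)(O)O[C@H]1CN[C@@H](C(=O)O)C1` is recorded as "not determined" (no result reported), and compound 2 `CCCCCCCCCCCCCCCC(=O)OCCCOP(=O)(O)O[C@H](C)[C@H](N)C(=O)O` is recorded as "not determined" (no result reported); no number is available for either. Among the measured compounds shown here, compound 3 `CCCCCCCCCCCC(=O)OC[C@@H](O)COP(=O)(O)O[C@H](C)[C@H](N)C(=O)O` is the one member with a reading: in this assay compound 3 gives 50 nM, and since no other number exists in the set, it stands alone and cannot be placed above or below anything. Nothing can be said of the pairs compound 1 with compound 3 or compound 2 with compound 3 beyond the fact that only compound 3 carries a value.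

The next entry, compound 4 `CCCCCCCCCCCCCCCC(=O)OC[C@@H](O)COP(=O)(O)O[C@H](C)[C@H](N)C(=O)O`, differs from compound 3 in one place: butyl in place of hydrogen on a saturated chain carbon, ten or more bonds along the chain from a carbonyl carbon. The acyl chain of compound 3 is lengthened, the rest of the structure — the glycerol-derived linker, the phosphate and the amino acid head — is kept.

For the measured compounds named here, no measured step exists in this set, so the size of the change from compound 3 to compound 4 in this assay rests on the structural change alone. The expectation is a small step, toward somewhat less compound needed, close to the usual scatter of the assay, expressed as a 1.7-fold lower number from compound 3 to compound 4 (0.22 log units; within the scatter). For compound 4 the estimated value in this assay is 30 nM, with a plausible range from 8 nM to 150 nM.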

Compound 4, half-maximal effective concentration: 20 nM
Estimate against measurement, compound 4: 1.5-fold (0.18 log units) above; low and high end bracket the measured number.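

In this assay, butyl in place of hydrogen on a saturated chain carbon, ten or more bonds along the chain from a carbonyl carbon, gives a 2.5-fold lower number from compound 3 to compound 4 (0.40 log units; beyond the scatter). Among the compounds shown here, this is the first measured step: the earlier compounds offered a single number and no comparison, whereas this modest step, beyond the scatter, shows that the read-out responds to a change this far along the chain and that the added butyl does not cost activity in this assay. No measurement at hand bears on the reason for this shift.

Going by these compounds, a single step gives no trend, so it remains open whether a longer chain at this place would lower the number further, leave it unchanged or raise it, and whether a chain carrying a terminal amine or carboxylic acid would be accepted there. On these data alone, it is equally open whether the same lengthening has a comparable effect with the other linker and head of compound 1 or compound 2, as neither has a number to compare.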